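Trimethoxyphenyl in Place of Hydroxyphenyl on a Saturated Carbon

This account rests on a few compounds, and the source may have more. Where it says the series, first, only, none or still open, it means among the compounds named here.

Measured compounds:
compound 1, `Cc1cc(O)c(C2=NN(c3ccc(S(N)(=O)=O)cc3)C(c3ccccc3O)C2)cc1Cl`, 4050 nM
compound 2, `Cc1cc(O)c(C2=NN(c3ccc(S(N)(=O)=O)cc3)C(c3ccccc3Cl)C2)cc1Cl`, 3390 nM
compound 3, `Cc1cc(O)c(C2=NN(c3ccc(S(N)(=O)=O)cc3)C(/C=C/c3ccccc3)C2)cc1Cl`, 10900 nM

In a functional assay on SK-MEL-28 cells (Homo sapiens) for antiproliferative activity, with a stated time of 48 h (on this read-out lower numbers stand for stronger inhibition of growth and higher numbers for weaker inhibition of growth), compound 1 gives 4050 nM, the second highest of the three numbers. The nearest step is a 1.2-fold lower number from compound 1 to compound 2 (0.08 log units; within the scatter), and the furthest is a 2.7-fold higher number from compound 1 to compound 3 (0.43 log units; beyond the scatter). Compound 4 `COc1ccc(C2CC(c3cc(Cl)c(C)cc3O)=NN2c2ccc(S(N)(=O)=O)cc2)c(OC)c1OC` differs from compound 1 in one place: 2,3,4-trimethoxyphenyl in place of 2-hydroxyphenyl on a saturated ring carbon. Among the measured compounds shown here, no measured step exchanges an aryl group on this carbon for another substituted aryl group; the only steps at this position, a 2.7-fold higher number from compound 1 to compound 3 (0.43 log units; beyond the scatter) and a 3.2-fold higher number from compound 2 to compound 3 (0.51 log units; beyond the scatter), replace aryl by 2-phenylethenyl and are modest, while a 1.2-fold lower number from compound 1 to compound 2 (0.08 log units; within the scatter) lies within the scatter. Compound 4 is therefore expected to give about 3000 nM, between 800 nM and 12000 nM, which would be a 1.4-fold lower number from compound 1 to compound 4 (0.13 log units; within the scatter).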

Compound 4, concentration for 50% growth inhibition: 3000 nM
Compound 4: middle estimate and measured number agree at the digits printed; the range from low to high includes it.
By their numbers in this assay, from the lowest: compounds 4, 2 and 1 (each within the scatter of the next); then compound 3.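

In this assay, this saturated ring carbon accepts the larger 2,3,4-trimethoxyphenyl, with 12 heavy atoms and 0 hydrogen-bond donors, with no change beyond the scatter: a 1.4-fold lower number from compound 1 to compound 4 (0.13 log units; within the scatter), and a 1.1-fold lower number from compound 2 to compound 4 (0.05 log units; within the scatter). The third step, a 3.6-fold lower number from compound 3 to compound 4 (0.56 log units; beyond the scatter), places this group with the other aryl groups, so compound 1, compound 2 and compound 4 all stand apart from compound 3. Nothing shown gives a reason for this result. From the compounds shown here alone, whether the arrangement of the methoxy groups matters remains open. So does the effect of a non-aromatic group on this carbon, such as an amine or a carboxylic acid.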